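Methylpiperazinyl for diethylamino on the propenamide chain

The source may hold more compounds than are shown below. What is called first, only, known or untested is meant among the compounds shown, and "the series" means these compounds.

Three compounds sharing a core are in hand. Compound 1 `COc1cc2ncnc(N3CCCc4ccccc43)c2cc1NC(=O)C=C(C)C` gives 5410 nM in a functional assay on A549 cells (Homo sapiens) for antiproliferative activity, read by MTT assay, with a stated time of 72 h; a higher number here means a weaker inhibitor, a lower number a stronger inhibitor. Compound 2 `COc1cc2ncnc(N3CCc4ccccc43)c2cc1NC(=O)/C=C/CN1CCN(C)CC1`, with a different saturated ring on the core, gives 5360 nM in this assay. Compound 3 `CCN(CC)C/C=C/C(=O)Nc1cc2c(N3CCCc4ccccc43)ncnc2cc1OC` gives 6410 nM in this assay; its number is the highest of the three, yet its distances to compound 1 and to compound 2 both lie within the scatter. For the measured compounds named here, the only single-point step measured, a 1.2-fold higher number from compound 1 to compound 3 (0.07 log units; within the scatter), shows no change beyond the scatter.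

The next compound, compound 4 `COc1cc2ncnc(N3CCCc4ccccc43)c2cc1NC(=O)/C=C/CN1CCN(C)CC1`, differs from compound 3 by 4-methylpiperazin-1-yl in place of diethylamino on a saturated chain carbon bound to a double-bonded chain carbon. Compound 2 carries the same 3-(4-methylpiperazin-1-yl)prop-1-en-1-yl group on a different core, and its value sits within the scatter of compound 3. On that basis, and on the flat step from compound 1 to compound 3, no change beyond the scatter is expected from the step of a 1.2-fold lower number from compound 3 to compound 4 (0.07 log units; within the scatter). Compound 4 is therefore estimated at 5500 nM in this assay, with a range from 2500 nM to 12000 nM.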

Compound 4, half-maximal inhibitory concentration: 7830 nM
The estimate for compound 4 lay 1.4-fold (0.15 log units) below the measured number; low and high end bracket the measured number.
By their numbers in this assay, from the lowest: compounds 2, 1, 3 and 4 (each within the scatter of the next).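

In this assay, the group on a saturated chain carbon bound to a double-bonded chain carbon can change from the open diethylamino to the ring-bearing 4-methylpiperazin-1-yl with no shift beyond the scatter (a 1.2-fold higher number from compound 3 to compound 4 (0.09 log units; within the scatter)). Compound 4 also closes two further single-place comparisons, both within the scatter: 1,2,3,4-tetrahydroquinolin-1-yl in place of 2,3-dihydro-1H-indol-1-yl on an aromatic carbon (a 1.5-fold higher number from compound 2 to compound 4 (0.16 log units; within the scatter)), and 3-(4-methylpiperazin-1-yl)prop-1-en-1-yl in place of 2-methylprop-1-en-1-yl on a carbonyl carbon (a 1.4-fold higher number from compound 1 to compound 4 (0.16 log units; within the scatter)). No evidence is available that bears on this result.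

From the compounds shown here alone, whether morpholin-4-yl, a carboxylic acid or a longer chain carrying the amine would move the number beyond the scatter remains open. The four compounds shown therefore mark no group at this position as better or worse than another.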